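A few compounds are considered here, and "the series" means these few. Any claim that something is new, unique, unknown or untested is made for them only; others in the source may bear on it.

Working notes on the series. Compound 1 `CCC(=O)c1ccc(OCCCCOc2ccc(F)c(C(=O)O)c2)c(C)c1O` gives 124 nM in an assay on HEK293 cells for positive allosteric modulation of metabotropic glutamate receptor 2 (Rattus norvegicus), read by thallium flux, with a stated time of 2.5 min (a lower number here means that less compound is needed, a higher number that more compound is needed for the effect), and stands at the low end of the two numbers in hand. Compound 3 `Cc1cc(OCCCCOc2ccc(C(=O)CC(C)C)c(O)c2C)ccc1C(=O)O` gives 173 nM in this assay, within the scatter of compound 1, so the two cannot be separated. For compound 2 `Cc1c(OCCCCOc2ccc(C(=O)O)cc2)ccc(C(=O)CC(C)C)c1C` the entry in this assay reads "not determined" (no result reported), so no number is in hand for it. Compound 4 `Cc1c(OCCCCOc2ccc(F)c(C(=O)O)c2)ccc(C(=O)C(C)C)c1O` differs from compound 1 by methyl in place of hydrogen on a saturated chain carbon bound to a carbonyl carbon and a saturated chain carbon. For the measured compounds named here, no measured pair shows this change, so its size is not known from the data; compounds 1 and 3 carry different chains at the carbonyl yet lie within the scatter of each other. The step of a 1.2-fold higher number from compound 1 to compound 4 (0.08 log units; within the scatter) is therefore expected to be small, not beyond the scatter, in either direction. Compound 4 is estimated at 150 nM, with a range from 60 nM to 400 nM.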

Compound 4, half-maximal effective concentration: 171 nM
Compound 4: the middle estimate sits 1.1-fold (0.06 log units) below what was measured, within the range that was stated.
By their numbers in this assay, from the lowest: compounds 1, 4 and 3 (each within the scatter of the next).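

For the compounds shown here, the first matched pair at this saturated chain carbon gives a 1.4-fold higher number from compound 1 to compound 4 (0.14 log units; within the scatter) in this assay, so the change from ethyl to isopropyl leaves the two compounds inseparable. One added methyl at this carbon is therefore tolerated in this single pair, on the core of compound 1. No data given bear on why the step is this small.

As far as these compounds go, whether a second methyl, giving tert-butyl, or an amine at this carbon would stay within the scatter remains open. So does whether the same step holds on other cores in the series.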